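Azide at the Chain End of Compound 1

The compounds below may be only part of what the source reports. "The series", "measured", "known", "first", "only" and "open" are said of these compounds alone.

Measured compounds:
compound 1 `CCCCC#Cc1cncc(OC[C@@H]2CCN2)c1` gives 0.1 nM in an assay on HEK293 cells for displacement of a labelled ligand from Neuronal acetylcholine receptor; alpha4/beta2 (Rattus norvegicus), read by scintillation counting; on this read-out lower numbers stand for stronger inhibition and higher numbers for weaker inhibition
compound 2 `c1ncc(-c2nnn3c2CCCC3)cc1OC[C@@H]1CCN1` gives 10 nM in this assay
compound 3 `CCCCC#Cc1cncc(OC[C@@H]2CCCN2)c1` gives 1.2 nM in this assay

Compound 1 has the lowest number of the three. Its nearest neighbour is compound 3, reached by the step of a 12-fold higher number from compound 1 to compound 3 (1.08 log units; beyond the scatter); compound 2, which differs from compound 1 in more than one place, lies furthest away, and the two values show the wider gap without any single-change step between them.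

Compound 4 `[N-]=[N+]=NCCCCC#Cc1cncc(OC[C@@H]2CCN2)c1` is not yet measured. It differs from compound 1 by azido in place of hydrogen on a saturated chain carbon, four bonds along the chain from a triple-bonded carbon. For the measured compounds named here, none of the measured steps touches this part of the molecule: the one single-change step, from compound 1 to compound 3, alters the saturated ring bound through the oxygen-linked carbon and says nothing about the far end of the chain. Going by the values given here, with no step bearing on the change, the expectation rests on compound 1 alone, and the new group adds only a small, uncharged tail. The step is expected to be a 2.5-fold higher number from compound 1 to compound 4 (0.40 log units; beyond the scatter), a modest drift at most. Compound 4 is therefore estimated at 0.25 nM, within 0.05 nM to 1.2 nM.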

Compound 4, inhibition constant: 0.086 nM
Compound 4: the middle estimate sits 2.9-fold (0.46 log units) above what was measured; low and high end bracket the measured number.
By their numbers in this assay, from the lowest: compounds 4 and 1 (each within the scatter of the next); then compound 3; then compound 2.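

Placing azido in place of hydrogen on a saturated chain carbon, four bonds along the chain from a triple-bonded carbon, gives in this assay the step of a 1.2-fold lower number from compound 1 to compound 4 (0.07 log units; within the scatter) and leaves compound 1 and compound 4 indistinguishable. For the compounds shown here, this is the first view of the far end of the chain, as the earlier single-change step touched only the saturated ring, and it shows that this position takes a group of three nitrogen atoms with no separation from hydrogen in the read-out. Nothing available explains this outcome.

As far as these compounds go, whether an amine or a carboxylic acid at the same chain end, or a longer chain, would give the same result remains open. Also open, from the compounds shown here alone, is whether azido would behave alike with pyrrolidin-2-yl in place of azetidin-2-yl.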